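Vero cytotoxicity notes: methoxyphenyl placement on the carbonyl

The source may hold more compounds than are shown below. What is called first, only, known or untested is meant among the compounds shown, and "the series" means these compounds.

Measured in an ADME assay on Vero cells (Chlorocebus sabaeus) for cytotoxicity, read by MTT assay, with a stated time of 72 h; on this read-out higher numbers stand for lower toxicity in this test and lower numbers for higher toxicity in this test:
compound 1 `COC(=O)c1cc(-c2cccc(NC(=O)c3ccc(/C=C/C(=O)c4cccc(C(F)(F)F)c4)cc3)c2)on1` — a limit only, > 20 ug/mL.
compound 2 `COC(=O)c1cc(-c2cccc(NC(=O)c3ccc(/C=C/C(=O)c4ccc(OC)cc4)cc3)c2)on1` — a limit only, > 10 ug/mL.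
compound 3 `CCCOc1ccc(C(=O)/C=C/c2ccc(C(=O)O)cc2)cc1` — a limit only, < 10 ug/mL.

All three values in this assay are limits, so compound 2 stands at one limit (the limit of > 10 ug/mL in this assay, at which 1 of the 3 values shown sits), compound 1 at another (the limit of > 20 ug/mL in this assay, at which 1 of the 3 values shown sits) and compound 3 at the third (the limit of < 10 ug/mL in this assay, at which 1 of the 3 values shown sits); none can be ranked against another. The step that the two limits leave unreadable from compound 1 to compound 2 is not readable. Compound 4 `COC(=O)c1cc(-c2cccc(NC(=O)c3ccc(/C=C/C(=O)c4cccc(OC)c4)cc3)c2)on1` differs from compound 2 by 3-methoxyphenyl in place of 4-methoxyphenyl on a carbonyl carbon. Going by the values given here, no measured step covers this change; the only step at this carbonyl carbon is the unreadable one from compound 1 to compound 2. The expectation therefore keeps compound 4 near compound 2, with a step that the limit leaves unreadable from compound 2 to compound 4 expected, nothing beyond the scatter. Compound 4 is estimated at 20 ug/mL, between 8 ug/mL and 50 ug/mL, most likely reported again only as a limit.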

Compound 4, half-maximal cytotoxic concentration: > 100 ug/mL
Compound 4: only a limit was reported (the forecaster's own chance of this, stated with the estimate: 70%); middle value at least 5.0-fold (0.69 log units) from the limit.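

Compound 4 is reported only as a limit, as are compound 1 and compound 2, so the steps among these three cannot be read. The compounds shown leave open whether 3-methoxyphenyl in place of 4-methoxyphenyl shifts the half-maximal cytotoxic concentration at all.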